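The source may report more compounds than this note shows. Statements on the series, on what has been measured and on what is new or still open speak of the compounds shown alone.

Measured so far:
compound 1 `O=C1CCCN1c1cnc(NCc2c(F)ccc3c2CCO3)c2cn[nH]c(=O)c12`: 1.8
compound 2 `C[C@H]1CC(=O)N(c2cnc(NCc3c(F)ccc4c3CCO4)n3cnnc23)C1`: 1.8

In a physicochemical assay for lipophilicity, using the shake flask method, in phosphate buffer, measured as octanol-water partition, with a stated time of 30 min, at pH 7.4 (a higher number here means a more lipophilic compound, a lower number a more polar compound), compound 1 gives 1.8. Compound 2 gives 1.8, which sits level with compound 1 within the usual scatter, so the two cannot be told apart on this measurement.

Compound 3 `Cc1nn(C)cc1-c1cnc(NCc2c(F)ccc3c2CCO3)c2cn[nH]c(=O)c12` has not yet been measured. Compared with compound 1 it carries 1,3-dimethyl-1H-pyrazol-4-yl in place of 2-oxopyrrolidin-1-yl on an aromatic carbon. Going by the values given here, no measured pair shows this exchange, so the expectation rests on the structures alone. The expected step is a number 0.60 log units higher from compound 1 to compound 3 (beyond the scatter), an increase beyond the scatter. Compound 3 is therefore estimated at 2.4, with a range from 1.9 to 2.9.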

Compound 3, distribution coefficient: 2.8
Estimate against measurement, compound 3: 0.40 log units below; low and high end bracket the measured number.
By their numbers in this assay, from the lowest: compounds 1 and 2 (each within the scatter of the next); then compound 3.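

In this assay the change from 2-oxopyrrolidin-1-yl to 1,3-dimethyl-1H-pyrazol-4-yl on the aromatic carbon of the shared core gives a clear rise, a number 1.00 log units higher from compound 1 to compound 3 (beyond the scatter) and so shows that the group at this position can move the number beyond the scatter. The earlier compounds shown here offered no single-place comparison that could show this. Nothing available explains the rise. This one exchange cannot separate the contribution of the new ring from that of its two methyl groups. Going by these compounds, how an amine or a carboxylic acid at this position would compare remains open.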